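This account rests on a few compounds, and the source may have more. Where it says the series, first, only, none or still open, it means among the compounds named here.

Numbers in a functional assay on cells (Cancer cell lines, Homo sapiens) for cytotoxicity, with a stated time of 48 h; a lower number here means a stronger inhibitor of growth, a higher number a weaker inhibitor of growth:

compound 1 `COc1cc2c(/C=C3/C(=O)Nc4cccc(Cl)c43)c(Cl)n(Cc3cc(OC)c(OC)c(OC)c3)c2cc1C` — 2950 nM
compound 2 `COc1c(/C=C2/C(=O)Nc3ccccc32)c2ccccc2n1-c1ccccc1` — 1230 nM
compound 3 `COc1c(/C=C2/C(=O)Nc3ccc(Cl)cc32)c2ccccc2n1-c1ccccc1` — 4270 nM

Compound 3 carries the highest of the three numbers. Going by the values given here, its nearest neighbour is compound 1, whose number is lower only within the scatter, so the two are not separable; compound 1 also differs from compound 3 in several places at once, so no single step can be drawn to it. Compound 2 is the clear neighbour: it differs from compound 3 in one place only, and that step is a 3.5-fold higher number from compound 2 to compound 3 (0.54 log units; beyond the scatter).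

Compound 4 `COc1ccc2c(c1)/C(=C\c1c(OC)n(-c3ccccc3)c3ccccc13)C(=O)N2` differs from compound 3 in one place: methoxy in place of chloro on an aromatic carbon. Among the compounds with values here, the only measured step that bears on this position is a 3.5-fold higher number from compound 2 to compound 3 (0.54 log units; beyond the scatter), a modest rise when the chloro arrived. Nothing measured shows what a methoxy does at this place; the change removes the chloro whose arrival gave that rise, yet it does not return the position to hydrogen, so a full reversal of that step cannot be assumed. The expectation for compound 4 is therefore a number that settles between those of compound 2 and compound 3, with an expected step of a 1.7-fold lower number from compound 3 to compound 4 (0.23 log units; within the scatter) that stays within the scatter. For compound 4 the estimate in this assay is 2500 nM, within a range of 1000 nM to 6500 nM.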

Compound 4, concentration for 50% growth inhibition: 630 nM
For compound 4 the middle estimate is 4.0-fold (0.60 log units) above the measured one; measured number below the stated range.
By their numbers in this assay, from the lowest: compounds 4 and 2 (each within the scatter of the next); then compounds 1 and 3 (each within the scatter of the next).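

In this assay this position proves sensitive to which group it carries, not merely to whether it is substituted: methoxy in place of chloro on this aromatic carbon gives a 6.8-fold lower number from compound 3 to compound 4 (0.83 log units; beyond the scatter), which clearly undoes the rise seen when chloro arrived, a 3.5-fold higher number from compound 2 to compound 3 (0.54 log units; beyond the scatter). Set against the hydrogen compound, methoxy gives a 2.0-fold lower number from compound 2 to compound 4 (0.29 log units; within the scatter), so hydrogen and methoxy are not separable here, and of the three groups seen at this place only chloro stands apart, with a number beyond the scatter from both others. Nothing available explains why chloro and methoxy part ways at this carbon.

Still open, going by these compounds, is how other groups would behave at this place, such as an amine, a carboxylic acid or a longer alkoxy chain, and so whether the tolerance seen for methoxy extends beyond that one group. Also open, on these data alone, is whether the same order of hydrogen, methoxy and chloro would hold on a differently substituted core such as that of compound 1, since all three steps rest on a single shared core.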